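Aryl Sulfonamide Piperidines and a Cytotoxicity Limit

The compounds below may be only part of what the source reports. "The series", "measured", "known", "first", "only" and "open" are said of these compounds alone.

Compound 1, `Cc1ccc(S(=O)(=O)N2CCC(N3CCC(C)CC3)CC2)cc1C`, in an ADME assay on HCT-116 cells (Homo sapiens) for cytotoxicity, read by CellTiter-Glo, with a stated time of 72 h; on this read-out lower numbers stand for stronger inhibition and higher numbers for weaker inhibition: > 5000 nM
Compound 2, `Cc1cc(C)c(S(=O)(=O)N2CCC(N3CCCCCC3)CC2)c(C)c1`, in this assay: > 5000 nM
Compound 3, `Cc1cc(C)c(S(=O)(=O)N2CCC(N3CC(C)CC(C)C3)CC2)c(C)c1`, in this assay: > 5000 nM

In this assay compound 1 gives only a limit, > 5000 nM, and not a number. Compound 2 likewise gives only a limit. Compound 3 gives only a limit as well. All three values therefore sit together at the limit of > 5000 nM in this assay, at which 3 of the 3 values shown sit, and nothing separates compound 1 from its neighbours on the numbers shown.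

Compound 4, `CC1CCN(C2CCN(S(=O)(=O)c3cccc(Br)c3)CC2)CC1`, differs from compound 1 by 3-bromophenyl in place of 3,4-dimethylphenyl on a sulfonyl sulfur. Going by the values given here, the one step between measured compounds that differ in a single place, a step that the two limits leave unreadable from compound 2 to compound 3, concerns the saturated amine rather than the aryl group, and the two limits leave its size unreadable. Among the compounds with values here, no measured step bears directly on the exchange of aryl groups from compound 1 to compound 4, so the expectation rests only on where the measured compounds stand.

Because every value shown sits at the limit of > 5000 nM in this assay, at which 3 of the 3 values shown sit, compound 4 is expected to stay there too. Compound 4 is estimated at 8000 nM, with a range from 3000 nM to 30000 nM. The step from compound 1 that this estimate means, a step that the limit leaves unreadable from compound 1 to compound 4, is expected to be no more than the scatter.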

Compound 4, half-maximal inhibitory concentration: > 5000 nM
Compound 4: only a limit was reported (the forecaster's own chance of this, stated with the estimate: 80%); the middle value does not contradict the limit.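

In this assay compound 4 gives > 5000 nM, which is a limit and not a number. Compound 1 also stands at a limit, so no step from compound 1 to compound 4 can be read: the limit of > 5000 nM in this assay, at which 4 of the 4 values shown sit.

The compounds shown leave open whether the aryl group or the saturated amine changes the read-out in this assay at all.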